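Fluorine position shift on the styryl phenyl of compound 3

The source may hold more compounds than are shown below. What is called first, only, known or untested is meant among the compounds shown, and "the series" means these compounds.

Going by the values given here, compound 3 `COC(=O)/C=C/c1cccc(N(Cc2ccc(/C=C/c3ccccc3F)cc2)C(=O)NC(C)C)c1` gives 431 nM in an assay on isolated protein with Bile acid receptor (Homo sapiens) as the target (on this read-out higher numbers stand for an effect only at larger amounts of compound and lower numbers for an effect already at smaller amounts), the highest number of the three measured here; compound 1 `COC(=O)/C=C/c1cccc(N(Cc2ccc(/C=C/c3cccc(C(F)(F)F)c3)cc2)C(=O)C(C)C)c1` gives 267 nM, a gap that lies within the scatter, while compound 2 `COC(=O)/C=C/c1cccc(N(Cc2ccc(/C=C/c3ccccc3F)cc2)C(=O)C2CCCCC2)c1` gives 64 nM, and the step of a 6.7-fold higher number from compound 2 to compound 3 (0.83 log units; beyond the scatter) is the only change beyond the scatter in this set. Compound 4 `COC(=O)/C=C/c1cccc(N(Cc2ccc(/C=C/c3ccc(F)cc3)cc2)C(=O)NC(C)C)c1` differs from compound 3 by 4-fluorophenyl in place of 2-fluorophenyl on a double-bonded chain carbon bound to a double-bonded chain carbon. Among the compounds with values here, no measured step touches the fluorine position on that ring, so nothing here points in either direction; the expected step of a 1.0-fold lower number from compound 3 to compound 4 (0.00 log units; within the scatter) is therefore none beyond the scatter. Compound 4 is estimated at 430 nM, with a range of 150 nM to 1300 nM, the width reflecting the absence of any bearing step.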

Compound 4, half-maximal effective concentration: 348 nM
For compound 4 the middle estimate is 1.2-fold (0.09 log units) above the measured one; the range from low to high includes it.
By their numbers in this assay, from the lowest: compound 2; then compounds 1, 4 and 3 (each within the scatter of the next).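

Moving the fluorine gives a 1.2-fold lower number from compound 3 to compound 4 (0.09 log units; within the scatter) in this assay and is the only read on this ring position in the series. With isopropylamino held on the carbonyl carbon, 2-fluorophenyl and 4-fluorophenyl are not separated, whereas a 6.7-fold higher number from compound 2 to compound 3 (0.83 log units; beyond the scatter) shows the carbonyl substituent change reaching beyond the scatter. Nothing at hand bears on the reason for this result.

As far as these compounds go, whether a methoxy or chlorine on that ring, or an unsubstituted phenyl, would move the number remains open. Also open, from the compounds shown here alone, is whether the fluorine shift reads the same with cyclohexyl on the carbonyl carbon.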